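Indole amides and a sulfonamide: from bromo to cyano

The compounds below may be only part of what the source reports. "The series", "measured", "known", "first", "only" and "open" are said of these compounds alone.

Measured so far:
- compound 1, `O=C(Nc1ccc2cc[nH]c2c1)c1ccc(Br)cc1`: 38100 nM
- compound 2, `O=C(Nc1ccc2cc[nH]c2c1)c1cccc(C(F)(F)F)c1`: 30600 nM
- compound 3, `O=S(=O)(Nc1ccc2cc[nH]c2c1)c1ccc(Cl)cc1`: 54000 nM

All three compounds share the same core and were run in a functional assay on MCF7 cells (Homo sapiens) for antiproliferative activity, read by MTT assay, with a stated time of 24 h; on this read-out higher numbers stand for weaker inhibition and lower numbers for stronger inhibition. Compound 1 gives 38100 nM, which is the second highest of the three numbers. Its nearest neighbour is compound 2, with 30600 nM, and the furthest is compound 3, with 54000 nM; both gaps to compound 1 lie within the usual scatter, so the three values cannot be ranked against each other. Going by the values given here, no step between measured compounds that differ in one place is available in this set.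

Compound 4, `N#Cc1ccc(C(=O)Nc2ccc3cc[nH]c3c2)cc1`, is not yet measured in this assay. Compared with compound 1 it carries cyano in place of bromo on an aromatic carbon. Among the compounds with values here, nothing among the measured compounds speaks to this change, and the three numbers in hand sit close together, so no step beyond the scatter is expected in either direction.

Compound 4 is therefore estimated at 35000 nM, with a range from 14000 nM to 90000 nM. The expected step is a 1.1-fold lower number from compound 1 to compound 4 (0.04 log units; within the scatter), which is within the scatter.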

Compound 4, half-maximal inhibitory concentration: 33600 nM
Compound 4: middle estimate off by 1.0-fold (0.02 log units), on the high side; the range from low to high includes it.
By their numbers in this assay, from the lowest: compounds 2, 4, 1 and 3 (each within the scatter of the next).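

In this assay, going by these compounds alone, replacing bromo with cyano on an aromatic carbon, para to a large group, gives a 1.1-fold lower number from compound 1 to compound 4 (0.05 log units; within the scatter), the first step between compounds that differ in one place. At this position, the read-out therefore does not separate the two groups, even though cyano brings a triple bond and a hydrogen-bond acceptor that bromo lacks, so this exchange gives no handle on the antiproliferative activity of the series. No measurement is available that bears on why these two groups read alike.

Going by these compounds, it remains open whether an amine, a carboxylic acid or a longer alkyl chain on the same aromatic carbon would give a step beyond the scatter, or whether any group at this position would move the number at all. The other differences among the compounds shown, including the amide and sulfonamide links and the placement of trifluoromethyl, occur only alongside a second change, so those steps cannot be read.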